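Fluoro on the pyridine of the thiomorpholine thiosemicarbazone

The compounds below may be only part of what the source reports. "The series", "measured", "known", "first", "only" and "open" are said of these compounds alone.

Measured so far:
compound 1, `N/C(=N\NC(=S)N1CCCC1)c1ccc(F)cn1`, 78.7% in a functional assay on A-431 cells (Homo sapiens) for cytotoxicity, read by MTT assay, with a stated time of 72 h, tested at 10 uM; a lower number here means less inhibition of growth, a higher number more inhibition of growth at the concentration tested;
compound 2, `N/C(=N\NC(=S)N1CCSCC1)c1ccccn1`, 61.4% in this assay;
compound 3, `N/C(=N\NC(=S)N1CCCCC1)c1ccccn1`, 68.1% in this assay.

Compound 2 has the lowest of the three numbers in this assay. Its nearest neighbour is compound 3, with a number 6.7 percentage points higher from compound 2 to compound 3 (within the scatter), a gap within the scatter. The furthest is compound 1, whose value lies beyond the scatter from that of compound 2, but compound 1 and compound 2 differ in two places, so the two values alone cannot be split into a ring effect and a fluoro effect.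

Compound 4, `N/C(=N\NC(=S)N1CCSCC1)c1ccc(F)cn1`, is compound 2 with fluoro in place of hydrogen on an aromatic carbon, at a position two atoms from the ring nitrogen and para to a large group. Within the data shown here, none of the measured steps carries this change on its own; the only single-point step, from compound 2 to compound 3, concerns the ring on the thiocarbonyl carbon and was within the scatter. The fluoro change is therefore unanchored, and only a modest rise is expected in this assay, in line with a number 6.6 percentage points higher from compound 2 to compound 4 (within the scatter). For compound 4 the estimate in this assay is 68%, within 55% to 81%.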

Compound 4, percent growth inhibition at one concentration: 61.8%
Compound 4: middle estimate off by 6.2 percentage points, on the high side, within the range that was stated.
By their numbers in this assay, from the lowest: compounds 2, 4 and 3 (each within the scatter of the next); then compound 1.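

With the thiomorpholin-4-yl ring held constant, fluoro in place of hydrogen on an aromatic carbon, two atoms from the ring nitrogen and para to a large group, gives a number 0.4 percentage points higher from compound 2 to compound 4 (within the scatter) in this assay, so this read-out does not separate fluoro from hydrogen at this position. Among these compounds, with fluoro held constant, thiomorpholin-4-yl in place of pyrrolidin-1-yl on the thiocarbonyl carbon gives a number 16.9 percentage points lower from compound 1 to compound 4 (beyond the scatter), the first single-place step beyond the scatter, which ties the high value of compound 1 (78.7%) to the ring on the thiocarbonyl carbon rather than to the fluoro. No measurement at hand bears on why either step has the size it has.

From the compounds shown here alone, it remains open whether fluoro at this position would also leave the value unmoved in the pyrrolidin-1-yl or piperidin-1-yl compounds, since the step from hydrogen to fluoro has been read only with the thiomorpholin-4-yl ring. Going by these compounds, it is also open whether a different group at the same position, such as an amine or a carboxylic acid, would shift the value where fluoro does not.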